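Ethyl for phenyl on the ring nitrogen, two cores

A few compounds are considered here, and "the series" means these few. Any claim that something is new, unique, unknown or untested is made for them only; others in the source may bear on it.

Compound 1 `CCOc1ccc(NC(=O)c2c(N)n[nH]c2Nc2ccccc2)cc1` and compound 3 `CCNc1[nH]nc(N)c1C(=O)Nc1ccc(OCC)cc1` share one core. In a functional assay on PANC-1 cells (Homo sapiens) for cytotoxicity, read by resazurin assay, with a stated time of 48 h (a higher number here means a weaker inhibitor, a lower number a stronger inhibitor), compound 1 gives 21000 nM and compound 3 gives 14800 nM. The change between them is ethyl in place of phenyl on a nitrogen on an aromatic ring, and it gave a 1.4-fold lower number from compound 1 to compound 3 (0.15 log units; within the scatter). Compound 2 `CCOc1ccc(-n2nnc3n[nH]c(Nc4ccccc4)c3c2=O)cc1` carries a second core; the difference between the two cores is not broken down here. In this assay compound 2 gives 13100 nM, a value within the scatter of both compound 3 and compound 1. Compound 4 `CCNc1[nH]nc2nnn(-c3ccc(OCC)cc3)c(=O)c12` applies the same change to compound 2: ethyl in place of phenyl on a nitrogen on an aromatic ring. In this assay, among the measured compounds shown here, the step from compound 2 to compound 4 is expected to be a 1.3-fold lower number from compound 2 to compound 4 (0.12 log units; within the scatter), resting on the one earlier step of a 1.4-fold lower number from compound 1 to compound 3 (0.15 log units; within the scatter), which stayed within the scatter. Compound 4 is therefore estimated at 10000 nM, with a range from 4500 nM to 24000 nM.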

Compound 4, half-maximal inhibitory concentration: 16100 nM
The estimate for compound 4 lay 1.6-fold (0.21 log units) below the measured number, and the stated range covers the measured number.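

In this assay, ethyl in place of phenyl on a nitrogen on an aromatic ring gives a 1.2-fold higher number from compound 2 to compound 4 (0.09 log units; within the scatter). Set beside the earlier step, the change shows no detectable difference between the two cores: the same change on two cores in this assay, a 1.4-fold lower number (0.15 log units; within the scatter) from compound 1 to compound 3 and a 1.2-fold higher number (0.09 log units; within the scatter) from compound 2 to compound 4, 1.7-fold (0.24 log units) apart, within the scatter of two such steps

This shows that the change stays within the scatter on both cores, so neither core gives a sign that phenyl and ethyl differ at this nitrogen. It does not show a shared direction or size of effect, and two steps cannot establish a rule for the series.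

The compounds shown leave open whether a longer chain such as butyl, a benzyl group or a cyclohexyl ring on that nitrogen would move the number beyond the scatter on either core.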